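Replacing the dimethylamino end of compound 3

The compounds below may be only part of what the source reports. "The series", "measured", "known", "first", "only" and "open" are said of these compounds alone.

Compound 1 `NCCCCN(C[C@H]1Cc2ncccc2CN1)[C@H]1CCCc2cccnc21`: 17 nm/s
Compound 2 `CN(C[C@H]1Cc2ncccc2CN1)[C@H]1CCCc2cccnc21`: 460 nm/s
Compound 3 `CN(C)CCCCN(C[C@H]1Cc2ncccc2CN1)[C@H]1CCCc2cccnc21`: 2 nm/s

These numbers come from an ADME assay for permeability, using PAMPA, with a stated time of 4 h, at pH 5.5; on this read-out higher numbers stand for higher permeability and lower numbers for lower permeability. Compound 3 has the lowest number of the three (2 nm/s), and both of the others lie beyond the scatter from it. The next compound to be measured is compound 4 `c1cnc2c(c1)CN[C@@H](CN(CCCCNC1COC1)[C@H]1CCCc3cccnc31)C2`, and the change that makes it from compound 3 is (oxetan-3-yl)amino in place of dimethylamino on a saturated chain carbon, four bonds along the chain from an amine nitrogen. In plain words, (oxetan-3-yl)amino stands in place of dimethylamino, while the rest of the molecule stays the same.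

Going by the values given here, the closest guide is the one measured swap at this same place, a modest step (an 8.5-fold lower number from compound 1 to compound 3 (0.93 log units; beyond the scatter)). Read backwards, it shows that leaving dimethylamino for a plain amino group went with a higher number. The two large steps, a 27-fold higher number from compound 1 to compound 2 (1.43 log units; beyond the scatter) and a 230-fold lower number from compound 2 to compound 3 (2.36 log units; beyond the scatter), involve removing or adding the whole side chain, which compound 4 keeps, so they bear on it less directly. Among the compounds with values here, no measured compound carries the entering group, so the guide is only partial. A modest rise is therefore expected in this assay (a 5.0-fold higher number from compound 3 to compound 4 (0.70 log units; beyond the scatter)). Compound 4 is estimated at 10 nm/s (expected range 2 nm/s to 50 nm/s).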

Compound 4, apparent permeability: 7 nm/s
Beside the measured number, compound 4's estimate is 1.4-fold (0.15 log units) above it; measured number inside the range.
By their numbers in this assay, from the lowest: compound 3; then compound 4; then compound 1; then compound 2.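

In this assay, the change from dimethylamino to (oxetan-3-yl)amino gives a 3.5-fold higher number from compound 3 to compound 4 (0.54 log units; beyond the scatter), so a second group in this place, on a saturated chain carbon four bonds along the chain from an amine nitrogen, also reads higher than dimethylamino. The plain amino group still reads highest of the three ends: putting oxetan-3-yl in place of hydrogen on that amine nitrogen gives a 2.4-fold lower number from compound 1 to compound 4 (0.39 log units; beyond the scatter), which leaves the (oxetan-3-yl)amino end between the other two. The step that adds the whole side chain remains much the largest, at a 66-fold lower number from compound 2 to compound 4 (1.82 log units; beyond the scatter), so neither new end brings the number close to that of compound 2, which has no such chain.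

Nothing in the data shown gives a reason for these differences. Still open, on these data alone, is how other ends would read in this place, such as a carboxylic acid or a morpholine ring, whether a cyclobutyl group on the same nitrogen would read like oxetan-3-yl, and what a shorter chain carrying (oxetan-3-yl)amino would give.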